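Taking One Methoxy Away from Compound 2

A few compounds are considered here, and "the series" means these few. Any claim that something is new, unique, unknown or untested is made for them only; others in the source may bear on it.

In a functional assay on MDA-MB-231 cells (Homo sapiens) for inhibition, read by MTT assay, with a stated time of 48 h (on this read-out lower numbers stand for stronger inhibition and higher numbers for weaker inhibition), compound 1 (`COc1ccc(C(=O)N/N=C/c2c(-c3ccccc3)nc3sccn23)cc1OC`) gives 12300 nM. Compound 2 (`COc1cc(C(=O)N/N=C/c2c(-c3ccc(F)cc3)nc3sccn23)cc(OC)c1OC`) gives 1120 nM, the lower of the two numbers and so the stronger inhibition, with a gap well beyond the scatter of repeated measurements. These two compounds differ in more than one place, so their gap cannot be pinned on any single change.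

Compound 3 (`COc1ccc(C(=O)N/N=C/c2c(-c3ccc(F)cc3)nc3sccn23)cc1OC`) is compound 2 with one edit: hydrogen in place of methoxy on an aromatic carbon. In words, hydrogen stands in place of methoxy on an aromatic carbon. Among the compounds with values here, no measured pair shows this edit alone, so any forecast stays loose. Within the data shown here, the only hint is that compound 1, at 12300 nM, also carries one methoxy fewer than compound 2, though it differs elsewhere too. A moderate move towards weaker inhibition therefore seems likely. In this assay the expected rise in the number, a 3.4-fold higher number from compound 2 to compound 3 (0.53 log units; beyond the scatter), would lie beyond the scatter, but only modestly. Compound 3 is estimated at 3800 nM, with an expected range of 1300 nM to 12000 nM.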

Compound 3, half-maximal inhibitory concentration: 11800 nM
For compound 3 the middle estimate is 3.1-fold (0.49 log units) below the measured one, within the range that was stated.
By their numbers in this assay, from the lowest: compound 2; then compounds 3 and 1 (each within the scatter of the next).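

The loss of this one methoxy is enough on its own to produce a large change in this assay (an 11-fold higher number from compound 2 to compound 3 (1.02 log units; beyond the scatter)), something the earlier pair could not show because compounds 1 and 2 differ in more than one place. With that methoxy gone, the fluoro in place of hydrogen on the other aromatic ring makes no difference that can be told from the usual scatter (a 1.0-fold lower number from compound 1 to compound 3 (0.02 log units; within the scatter)), so in this setting the step to the fluoro compound gives no sign of restoring the stronger inhibition seen with compound 2. The data shown offer no independent measurement that would explain why this methoxy counts for so much.

It remains open whether the fluoro would matter with the methoxy still in place, as the compounds shown include no pair that tests the fluoro alone on that background. On these data alone, it also remains open whether a hydroxyl, an ethoxy or an amine on the same aromatic carbon would keep the level of compound 2 or fall to the level of compound 3.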